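Swapping chloro for fluoro on a short-lived compound

The source may report more compounds than this note shows. Statements on the series, on what has been measured and on what is new or still open speak of the compounds shown alone.

Measured so far:
compound 1 `Fc1ccc2c(-c3ccc4ccccc4n3)c[nH]c2c1Cl` gives 0.183 h in an ADME assay on microsomes from liver (Homo sapiens) for metabolic stability, using NADPH, with a stated time of 40 min, tested at 2 uM; on this read-out higher numbers stand for a longer-lived compound and lower numbers for a shorter-lived compound
compound 2 `Clc1cccc2c(-c3ccc4ccccc4n3)c[nH]c12` gives 0.283 h in this assay

Going by the values given here, compound 1 at 0.183 h lies within the scatter of its only neighbour, compound 2 at 0.283 h, so the two cannot be ranked. Compound 3 (`Fc1ccc2c(-c3ccc4ccccc4n3)c[nH]c2c1F`) has not yet been measured. It differs from compound 1 in one place, with fluoro in place of chloro on an aromatic carbon, ortho to a fluoro group (fluoro in place of chloro on an aromatic carbon). Among the compounds with values here, no measured step exchanges chloro itself. The nearest evidence is a 1.5-fold higher number from compound 1 to compound 2 (0.19 log units; within the scatter), which is hydrogen in place of fluoro on an aromatic carbon and stays within the scatter. That small step bears only indirectly, and it gives no reason to expect a real shift in this assay. The estimated step is a 1.2-fold higher number from compound 1 to compound 3 (0.08 log units; within the scatter), which is none beyond the scatter. For compound 3 the expected half-life is 0.22 h, with an estimated range from 0.11 h to 0.42 h.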

Compound 3, half-life: 0.167 h
For compound 3 the middle estimate is 1.3-fold (0.12 log units) above the measured one; measured number inside the range.
By their numbers in this assay, from the lowest: compounds 3, 1 and 2 (each within the scatter of the next).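

Exchanging chloro for fluoro on this aromatic carbon, ortho to a fluoro group, gives a 1.1-fold lower number from compound 1 to compound 3 (0.04 log units; within the scatter) in this assay. Going by these compounds alone, this is the first step that exchanges the chloro itself, and it shows that the two halogens cannot be told apart at this position on this read-out. No measurement shown here bears on why the two compounds read alike.

All the changes shown so far involve only hydrogen, fluoro or chloro on the shared core, so it remains open whether a different kind of group at this position, such as a methoxy group, an amine or a nitrile, would move the half-life beyond the scatter. On these data alone, it is also open whether hydrogen at this same position would do so.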